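The compounds below may be only part of what the source reports. "The series", "measured", "known", "first", "only" and "open" are said of these compounds alone.

Of the compounds shown here, three built on one shared core have been tested in a functional assay on DU-145 cells (Homo sapiens) for inhibition, read by trypan blue exclusion, with a stated time of 96 h; a higher number here means a weaker inhibitor of growth, a lower number a stronger inhibitor of growth. Compound 2, `Cc1ccc(CS/C(=C/c2sccc2C)C(=O)c2ccc(Cl)cc2)cc1`, gives 10000 nM. Compound 1, `Cc1ccsc1/C=C(/SCc1ccc(Cl)cc1)C(=O)c1ccc(Cl)cc1`, gives 50000 nM, and compound 3, `Cc1ccsc1/C=C(/SCc1ccc(F)cc1)C(=O)c1ccc(Cl)cc1`, gives 50000 nM. Compound 2 thus holds the lowest number of the three: there is a 5.0-fold lower number from compound 1 to compound 2 (0.70 log units; beyond the scatter) and a 5.0-fold higher number from compound 2 to compound 3 (0.70 log units; beyond the scatter), whereas there is no change at the digits printed from compound 1 to compound 3 (within the scatter).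

Compound 4, `Cc1ccc(CS/C(=C/c2cccc(Cl)c2Cl)C(=O)c2ccc(Cl)cc2)cc1`, has not yet been measured. It differs from compound 2 in a single place: 2,3-dichlorophenyl in place of 3-methylthiophen-2-yl on a double-bonded chain carbon bound to a double-bonded chain carbon. The three measured steps all concern a small substituent on a different aromatic ring, exchanging methyl, chloro and fluoro; none of them touches the position changed here, and none exchanges a five-membered ring for a six-membered one. Among the measured compounds shown here, no measured step therefore bears on this change, and the direction of the step in this assay cannot be read from the measured compounds. The estimated step from compound 2 onward is a 1.5-fold higher number from compound 2 to compound 4 (0.18 log units; within the scatter), a guess carrying wide uncertainty. Compound 4 is accordingly expected to give 15000 nM, with a range from 3000 nM to 50000 nM.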

Compound 4, concentration for 50% growth inhibition: 25000 nM
For compound 4 the middle estimate is 1.7-fold (0.22 log units) below the measured one, and the stated range covers the measured number.
By their numbers in this assay, from the lowest: compound 2; then compounds 4, 1 and 3 (each within the scatter of the next).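

In this assay, replacing 3-methylthiophen-2-yl with 2,3-dichlorophenyl gives a 2.5-fold higher number from compound 2 to compound 4 (0.40 log units; beyond the scatter), which shows that the group on this double-bonded chain carbon also affects the read-out, not only the small substituent on the other aromatic ring. This single step changes several things at once: a five-membered aromatic ring with sulfur leaves, and a six-membered carbon-only ring carrying chlorine enters, so the effects of ring size, sulfur and chlorine cannot be separated. No measurement shown here explains the direction or size of this step.

On these data alone, it remains open whether a plain phenyl, a pyridine ring or a phenyl bearing an amine at this place would give a lower or higher number. Also open, as far as these compounds go, is whether this step would keep its size with chloro or fluoro in place of methyl on the other aromatic ring.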